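Aryl substituent swap on the shared core: compound 3

This account rests on a few compounds, and the source may have more. Where it says the series, first, only, none or still open, it means among the compounds named here.

Two members of the series have numbers in a functional assay on MCF7 cells (Homo sapiens) for cytotoxicity, read by MTT assay, with a stated time of 48 h; on this read-out lower numbers stand for stronger inhibition and higher numbers for weaker inhibition. Compound 1 `Cc1cccc(-n2cc(COC(=O)c3cc4ccccc4[nH]3)nn2)c1C` gives 17100 nM, and compound 2 `CCCCc1ccc(-n2cc(COC(=O)c3cc4ccccc4[nH]3)nn2)cc1` gives 28800 nM. Compound 2 holds the higher of the two numbers, yet the gap to compound 1 lies within the scatter, so the two stand level and nothing is made of the order. Within the data shown here, no pair of measured compounds differs in one place, so no single-change step is available as a yardstick. Compound 3 `COc1ccc(-n2cc(COC(=O)c3cc4ccccc4[nH]3)nn2)cc1` is the next member; against compound 2 the change is methoxy in place of butyl on an aromatic carbon. Among the measured compounds shown here, with no comparable step on record, the expected step for this change is one no larger than the scatter and without a settled direction, a 1.2-fold lower number from compound 2 to compound 3 (0.06 log units; within the scatter). Compound 3 is therefore estimated at 25000 nM, with a range from 10000 nM to 60000 nM.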

Compound 3, half-maximal inhibitory concentration: 16200 nM
For compound 3 the middle estimate is 1.5-fold (0.19 log units) above the measured one; measured number inside the range.
By their numbers in this assay, from the lowest: compounds 3, 1 and 2 (each within the scatter of the next).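

In this assay the series now has its first single-place steps: methoxy in place of butyl on an aromatic carbon, para to a large group, gives a 1.8-fold lower number from compound 2 to compound 3 (0.25 log units; within the scatter) and 4-methoxyphenyl in place of 2,3-dimethylphenyl on an aromatic nitrogen gives a 1.1-fold lower number from compound 1 to compound 3 (0.02 log units; within the scatter) as its step. Both steps lie within the scatter, so neither the exchange of butyl for methoxy, which brings in a hydrogen-bond acceptor, nor the exchange of the whole aryl group separates these compounds on this read-out. No measured property bears on this result, so the data offer no explanation for it.

As far as these compounds go, whether an amine, a carboxylic acid or a longer chain at this aromatic carbon would give a step beyond the scatter stays open. Also open, from the compounds shown here alone, is whether a change elsewhere on the shared core would give such a step.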